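Acetamido in place of aminomethyl on a shared core

The compounds below may be only part of what the source reports. "The series", "measured", "known", "first", "only" and "open" are said of these compounds alone.

Compound 1 `COc1cc(Nc2nc(NCc3cccnc3N(C)S(C)(=O)=O)c3c(F)c[nH]c3n2)cc(OC)c1OC` and compound 2 `CN(c1ncccc1CNc1nc(Nc2cccc(CN)c2)nc2[nH]cc(F)c12)S(C)(=O)=O` share one core and differ only in the group on one nitrogen. In a functional assay on SMMC-7721 cells (Homo sapiens) for inhibition, read by MTT assay, with a stated time of 48 h (a lower number here means a stronger inhibitor, a higher number a weaker inhibitor), compound 1 reaches only the limit of the assay, > 100000 nM. In this assay compound 2 likewise reaches only the limit, > 100000 nM. The step that the two limits leave unreadable from compound 1 to compound 2 therefore cannot be read, because of the limit of > 100000 nM in this assay, at which 2 of the 2 values shown sit. Compound 3 `CC(=O)Nc1cccc(Nc2nc(NCc3cccnc3N(C)S(C)(=O)=O)c3c(F)c[nH]c3n2)c1` differs from compound 2 by acetamido in place of aminomethyl on an aromatic carbon. Within the data shown here, no measured step bears on this change, and both measured compounds sit at the limit, so a step that the limit leaves unreadable from compound 2 to compound 3 is expected, most likely leaving compound 3 at the limit. Compound 3 is estimated at 150000 nM, within 30000 nM to 600000 nM.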

Compound 3, half-maximal inhibitory concentration: 16000 nM
Compound 3: the middle estimate sits 9.4-fold (0.97 log units) above what was measured; the measured number lies below the stated range.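

Among these compounds, this is the first readable change at this position: in this assay, acetamido in place of aminomethyl gives an at least 6.2-fold lower number from compound 2 to compound 3 (0.79 log units; beyond the scatter). Replacing 3,4,5-trimethoxyphenyl with 3-acetamidophenyl likewise gives an at least 6.2-fold lower number from compound 1 to compound 3 (0.79 log units; beyond the scatter), so only the acetamido compound of these three gives a number rather than a limit. From the compounds shown here alone, the true size of both steps stays open because each starting compound gives only a limit: the limit of > 100000 nM in this assay, at which 2 of the 3 values shown sit.

Going by these compounds, whether a propanamido group, with its longer chain, or a methanesulfonamido group would match or exceed acetamido remains open.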